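Moving a nitro group on a weak HL-60 inhibitor

A few compounds are considered here, and "the series" means these few. Any claim that something is new, unique, unknown or untested is made for them only; others in the source may bear on it.

In a functional assay on HL-60 cells (Homo sapiens) for inhibition, read by CCK-8 assay, with a stated time of 48 h (a higher number here means a weaker inhibitor, a lower number a stronger inhibitor), compound 2 `O=[N+]([O-])c1ccc(NC(=S)NCCNS(=O)(=O)c2ccc(-c3ccccc3OCc3cccc(O)c3)s2)cc1` gives 10800 nM, and compound 3 `O=[N+]([O-])c1cccc(NC(=S)NCCNS(=O)(=O)c2ccc(-c3ccccc3OCc3cccc(O)c3)s2)c1` gives 11400 nM. Between them lies one change, (4-nitrophenyl in place of 3-nitrophenyl on an amide-type nitrogen), and the step it made was a 1.1-fold lower number from compound 3 to compound 2 (0.02 log units; within the scatter). Compound 1 `COc1ccc(Oc2ccccc2-c2ccsc2S(=O)(=O)N2CCN(C(=O)Nc3cccc([N+](=O)[O-])c3)CC2)cc1OC` gives only a limit in this assay, > 50000 nM, which is the limit of > 50000 nM in this assay, at which 1 of the 3 values shown sits. How the core of compound 1 differs from that of compound 3 is not broken down here. Compound 4 `COc1ccc(Oc2ccccc2-c2ccsc2S(=O)(=O)N2CCN(C(=O)Nc3ccc([N+](=O)[O-])cc3)CC2)cc1OC` carries the change (4-nitrophenyl in place of 3-nitrophenyl on an amide-type nitrogen); the amide-type nitrogen here neighbours a carbonyl carbon rather than a thiocarbonyl carbon, so this is the same kind of change, not the same. The step is expected to be a step that the limit leaves unreadable from compound 1 to compound 4, because a 1.1-fold lower number from compound 3 to compound 2 (0.02 log units; within the scatter) stayed within the scatter. Compound 4 is therefore estimated at 60000 nM, likely between 30000 nM and 150000 nM.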

Compound 4, half-maximal inhibitory concentration: > 50000 nM
Compound 4 gave a limit, no number; the forecaster's own chance of this, stated with the estimate: 80%; the middle value does not contradict the limit.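

Compound 1 and compound 4 both sit at a limit rather than a number, so no step between them can be read: the limit of > 50000 nM in this assay, at which 2 of the 4 values shown sit.

The compounds shown leave open whether 4-nitrophenyl in place of 3-nitrophenyl changes anything for compound 1 and compound 4 in this assay.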